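The source may hold more compounds than are shown below. What is called first, only, known or untested is meant among the compounds shown, and "the series" means these compounds.

Compound 1 `O=[N+]([O-])c1ccc(NN=C(c2ccccc2O)c2ccccc2O)c([N+](=O)[O-])c1`; in a functional assay on cells (Melanoma tumor cell line, Homo sapiens) for cytotoxicity (on this read-out higher numbers stand for weaker inhibition and lower numbers for stronger inhibition), compound 1 gives 4.7 ug/mL.
Compound 2 `O=[N+]([O-])c1ccc(N/N=C(\c2ccccc2)c2ccc(O)cc2)c([N+](=O)[O-])c1`; in this assay compound 2 gives 5 ug/mL.
Compound 3 `O=[N+]([O-])c1ccccc1NN=C(c1ccc(O)cc1)c1ccc(O)cc1`; in this assay compound 3 gives 3.9 ug/mL.

Among these three numbers compound 3 has the lowest, yet its gaps to compound 1 and to compound 2 both lie within the scatter, so no ordering of the three can be claimed. Compound 4 `Oc1ccc(C(=NNc2ccccc2)c2ccc(O)cc2)cc1` has not been measured in this assay. It differs from compound 3 in one place: hydrogen in place of nitro on an aromatic carbon. Among the compounds with values here, no measured pair shows this change on its own; all three measured compounds carry nitro and sit close together, which gives no ground for expecting a large shift. The expected step is therefore small, a 1.5-fold higher number from compound 3 to compound 4 (0.19 log units; within the scatter), possibly toward a somewhat higher number but not clearly beyond the scatter. Compound 4 is estimated at 6 ug/mL, within a range from 2.5 ug/mL to 15 ug/mL.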

Compound 4, half-maximal inhibitory concentration: > 5 ug/mL
Compound 4 gave a limit, no number; the forecaster's own chance of this, stated with the estimate: 10%; the middle value lies beyond the limit too.
By their numbers in this assay, from the lowest: compounds 3, 1 and 2 (each within the scatter of the next).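

Compound 4 gives > 5 ug/mL in this assay, which is a limit and not a number. Hydrogen in place of nitro, on an aromatic carbon ortho to a large group, gives an at least 1.2-fold higher number from compound 3 to compound 4 (0.10 log units; that floor lies within the scatter). This pair shows the change on its own for the first time among these compounds, but it bounds the step from one side only: the limit of > 5 ug/mL in this assay, at which 1 of the 4 values shown sits.

Going by these compounds, how far the true value of compound 4 lies past that limit stays open, and with it whether removing nitro matters beyond the scatter. Also open, on these data alone, is how an amine or a carboxylic acid would compare with nitro on this carbon.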